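A few compounds are considered here, and "the series" means these few. Any claim that something is new, unique, unknown or untested is made for them only; others in the source may bear on it.

Compound 1 `Cn1ncc2c(=O)n(-c3ccccc3)c(SC(C)(C)c3ccccc3)nc21` gives 2200 nM in an assay on isolated protein for inhibition of retinal dehydrogenase 2 (Homo sapiens); on this read-out higher numbers stand for weaker inhibition and lower numbers for stronger inhibition.
Compound 2 `COc1cccc(C(C)Sc2nc3c(cnn3C)c(=O)n2-c2ccccc2)c1` gives 108 nM in this assay.
Compound 3 `CC(Sc1nc2c(cnn2C)c(=O)n1-c1ccccc1)c1cccnc1` gives 89 nM in this assay.

Of these three numbers, compound 3 has the lowest. Its nearest neighbour is compound 2, and the step of a 1.2-fold lower number from compound 2 to compound 3 (0.08 log units; within the scatter) lies within the scatter, so the two cannot be ordered. The step of a 25-fold lower number from compound 1 to compound 3 (1.39 log units; beyond the scatter) is large, but it combines a change of the chain with a change of the ring, since compound 1 carries a 1-methyl-1-phenylethyl group on the sulfur.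

Compound 4 `CC(Sc1nc2c(cnn2C)c(=O)n1-c1ccccc1)c1cccc(O)c1` has not yet been measured in this assay. It differs from compound 3 in one place: 3-hydroxyphenyl in place of pyridin-3-yl on a saturated chain carbon bound to a saturated chain carbon and a sulfur. The measured step that bears on this change is a 1.2-fold lower number from compound 2 to compound 3 (0.08 log units; within the scatter), in which a 3-methoxyphenyl ring and a pyridin-3-yl ring on the same chain carbon gave numbers within the scatter. Among the compounds with values here, no measured compound carries a hydroxyl on this ring, so the expectation rests on that single comparison. A step of a 1.1-fold higher number from compound 3 to compound 4 (0.05 log units; within the scatter) is expected, that is, none beyond the scatter. Compound 4 is therefore estimated at 100 nM, within a range from 40 nM to 250 nM.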

Compound 4, half-maximal inhibitory concentration: 100 nM
Estimate against measurement, compound 4: no gap at the digits printed; low and high end bracket the measured number.
By their numbers in this assay, from the lowest: compounds 3, 4 and 2 (each within the scatter of the next); then compound 1.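

In this assay, a free hydroxyl on the ring at this chain carbon gives a number within the scatter of both earlier rings: a 1.1-fold higher number from compound 3 to compound 4 (0.05 log units; within the scatter) brings in a hydrogen-bond donor where pyridin-3-yl has none, and a 1.1-fold lower number from compound 2 to compound 4 (0.03 log units; within the scatter) puts hydrogen in place of methyl on the oxygen. Across compounds 2, 3 and 4, then, this position accepts 3-methoxyphenyl, pyridin-3-yl and 3-hydroxyphenyl without any measurable separation, and the large 22-fold lower number from compound 1 to compound 4 (1.34 log units; beyond the scatter) stands apart from these small steps, although it joins a change of the ring with a change of the chain on the sulfur and so cannot be given to either one alone. No measurement is available that explains why these three rings cannot be told apart in this assay.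

The compounds shown leave open whether a group of another kind on this ring, such as an amine or a carboxylic acid, would also stay within the scatter of these three. They also leave open how much of the large step belongs to the chain alone, which a compound with 3-hydroxyphenyl on the 1-methyl-1-phenylethyl type of chain, or a longer chain on the same carbon, could separate.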